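A few compounds are considered here, and "the series" means these few. Any claim that something is new, unique, unknown or untested is made for them only; others in the source may bear on it.

The measured compounds:
compound 1, `CCCCCCc1ccc(-c2c(C)[nH]c(=O)n2C)cc1`, 9000 nM
compound 2, `CCCCCCCCCCc1ccc(-c2c(C)[nH]c(=O)n2C)cc1`, 7900 nM
compound 3, `CCCCCCCCCCCCCCc1ccc(-c2c(C)[nH]c(=O)n2C2CCCCC2)cc1`, > 100000 nM

In a functional assay on brain (Rattus norvegicus, strain Wistar) for inhibition (on this read-out lower numbers stand for stronger inhibition and higher numbers for weaker inhibition), compound 1 gives 9000 nM and compound 2 gives 7900 nM. The change between them is butyl in place of hydrogen on a saturated chain carbon, six bonds along the chain from an aromatic carbon, and the step it made is a 1.1-fold lower number from compound 1 to compound 2 (0.06 log units; within the scatter). For compound 3 the result is a limit of the assay, > 100000 nM, one of the values sitting at the limit of > 100000 nM in this assay, at which 1 of the 3 values shown sits. The difference between the core of compound 1 and the core of compound 3 is not broken down here. Compound 4, `CCCCCCCCCCCCCCCCCCc1ccc(-c2c(C)[nH]c(=O)n2C2CCCCC2)cc1`, is not yet measured; it differs from compound 3 by butyl in place of hydrogen on a saturated chain carbon, ten or more bonds along the chain from an aromatic carbon. This is the same kind of change as from compound 1 to compound 2, though the place on the chain differs, as the two described differences show. Resting on a 1.1-fold lower number from compound 1 to compound 2 (0.06 log units; within the scatter), the expected step is a step that the limit leaves unreadable from compound 3 to compound 4. Compound 4 is therefore estimated at 200000 nM, between 50000 nM and 1000000 nM, most likely again reported only as a limit.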

Compound 4, half-maximal inhibitory concentration: > 100000 nM
Compound 4 gave a limit, no number (the forecaster's own chance of this, stated with the estimate: 85%); the middle value does not contradict the limit.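

Compound 3 and compound 4 each give only a limit of the assay, and no step between them can be read: the limit of > 100000 nM in this assay, at which 2 of the 4 values shown sit.

The compounds shown leave open what butyl in place of hydrogen at this place on the chain does to inhibition.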